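This account rests on a few compounds, and the source may have more. Where it says the series, first, only, none or still open, it means among the compounds named here.

Compound 1 `O=C1O[C@H]([C@@H](O)Cn2cc(-c3ccc(Br)cc3)nn2)C(OCc2ccccc2)=C1OCc1ccccc1` — in a functional assay on HCT-116 cells (Homo sapiens) for antiproliferative activity, read by MTT assay, with a stated time of 72 h (on this read-out higher numbers stand for weaker inhibition and lower numbers for stronger inhibition), compound 1 gives 9420 nM
Compound 2 `Cc1ccc(-c2cn(C/C=C3\OC(=O)C(OCc4ccccc4)=C3OCc3ccccc3)nn2)cc1` — for compound 2 the value is > 100000 nM, a limit of the assay
Compound 3 `CCCCCc1ccc(-c2cn(C/C=C3\OC(=O)C(OCc4ccccc4)=C3OCc3ccccc3)nn2)cc1` — for compound 3 the value is > 100000 nM, likewise a limit of the assay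

Among the three measured compounds, compound 1 stands as the only one with a number in this assay; the two other values are limits. Among the measured compounds shown here, the one step between compounds that differ in a single place, a step that the two limits leave unreadable from compound 2 to compound 3, cannot be read, since both ends rest on (the limit of > 100000 nM in this assay, at which 2 of the 3 values shown sit). For the measured compounds named here, no measured step therefore bears on a change of the kind that leads from compound 1 to the unmeasured compound 4 `O=C1O[C@H]([C@@H](O)Cn2cc(CNS(=O)(=O)c3ccc(Cl)cc3)nn2)C(OCc2ccccc2)=C1OCc1ccccc1`, which differs from compound 1 by (((4-chlorophenyl)sulfonyl)amino)methyl in place of 4-bromophenyl on an aromatic carbon. The shared core is kept, and the change falls on the aromatic carbon of the five-membered aromatic ring with three nitrogens.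

With nothing to read from the measured steps, the expectation for compound 4 rests on compound 1 alone, whose value of 9420 nM is the only anchor. For compound 4 the estimate in this assay is 12000 nM, with a range from 2500 nM to 60000 nM. This estimate corresponds to an expected step of a 1.3-fold higher number from compound 1 to compound 4 (0.11 log units; within the scatter), which is not expected to lie beyond the scatter in either direction.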

Compound 4, half-maximal inhibitory concentration: 8380 nM
Compound 4: middle estimate off by 1.4-fold (0.16 log units), on the high side, and the stated range covers the measured number.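

At the aromatic carbon of the five-membered aromatic ring with 3 nitrogen, replacing 4-bromophenyl with (((4-chlorophenyl)sulfonyl)amino)methyl gives, in this assay, a 1.1-fold lower number from compound 1 to compound 4 (0.05 log units; within the scatter). Among the compounds shown here, this is the first readable step, and it shows that two quite different groups at this carbon can leave the values within the scatter of each other: the entering group has 12 heavy atoms against 7 for the group it replaces, and it carries 1 hydrogen-bond donor and 2 hydrogen-bond acceptors where the leaving group has none. No measurement shown here accounts for this outcome.

From the compounds shown here alone, this single pair sets no trend, so it remains open whether the same holds for other groups on that carbon, such as an aminomethyl group or a carboxylic acid. It also remains open what the chlorine of compound 4 or the bromine of compound 1 contributes, since no compound shown with the shared core carries a hydrogen in its place.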